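From Phenyl to Pyridin-2-yl on an Amine Nitrogen

The source may report more compounds than this note shows. Statements on the series, on what has been measured and on what is new or still open speak of the compounds shown alone.

In a functional assay on T-24 cells (Homo sapiens) for cytotoxicity, read by colorimetric assay and MTT assay (a higher number here means a weaker inhibitor, a lower number a stronger inhibitor), compound 1 (`COc1cccc2cc(-c3ccccc3)c(O)nc12`) gives 10000 nM and compound 2 (`Oc1ccc(-c2cc3c(O)cc(O)cc3nc2O)cc1`) gives 10000 nM while compound 3 (`COc1ccc(-c2cc3c(OC)cc(OC)cc3n(C)/c2=N\Nc2ccccc2)cc1`) gives 10000 nM as well. Compound 3 therefore stands level with compounds 1 and 2, and the three values do not separate. Compound 4 (`COc1ccc(-c2cc3c(OC)cc(OC)cc3n(C)/c2=N\Nc2ccccn2)cc1`) carries pyridin-2-yl in place of phenyl on an amine nitrogen and is otherwise the same as compound 3. For the measured compounds named here, no measured pair shows a change of this kind, so the expectation is loose. The expected step is a 2.5-fold lower number from compound 3 to compound 4 (0.40 log units; beyond the scatter) in this assay and is a modest one toward stronger inhibition. The estimate for compound 4 is 4000 nM with an expected range from 800 nM to 12000 nM in this assay.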

Compound 4, half-maximal inhibitory concentration: 10000 nM
Beside the measured number, compound 4's estimate is 2.5-fold (0.40 log units) below it; the range from low to high includes it.
By their numbers in this assay, from the lowest: compounds 1, 2, 3 and 4 (each within the scatter of the next).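

Pyridin-2-yl in place of phenyl on an amine nitrogen gives no change at the digits printed from compound 3 to compound 4 (within the scatter) in this assay and is the first step at this position that can be read. Exchanging phenyl for pyridin-2-yl, which brings one hydrogen-bond acceptor, does not separate the two compounds in this assay. Nothing at hand bears on this result.

From the compounds shown here alone, whether a benzyl group or pyrimidin-2-yl on this amine nitrogen would separate from compound 3 stays open. So does the effect of a carboxylic acid or an amine on the phenyl ring.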